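Toxicity series: thiophene replaces fluorophenyl on the amide

A few compounds are considered here, and "the series" means these few. Any claim that something is new, unique, unknown or untested is made for them only; others in the source may bear on it.

Measured compounds:
Compound 1 `CCCC(=O)Nc1ccc(N2CCN(c3ccc(OC[C@@H]4CO[C@@](Cn5cncn5)(c5ccc(Cl)cc5Cl)O4)cc3)CC2)cc1`: in a toxicity assay on L02 cells (Homo sapiens) for inhibition, read by MTT assay, with a stated time of 48 h (on this read-out lower numbers stand for stronger inhibition and higher numbers for weaker inhibition), compound 1 gives > 50000 nM, which is a limit of the assay and not a number.
Compound 2 `CCC(=O)Nc1ccc(N2CCN(c3ccc(OC[C@@H]4CO[C@@](Cn5cncn5)(c5ccc(Cl)cc5Cl)O4)cc3)CC2)cc1`: in this assay compound 2 gives > 50000 nM, again a limit.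
Compound 3 `O=C(Nc1ccc(N2CCN(c3ccc(OC[C@@H]4CO[C@@](Cn5cncn5)(c5ccc(Cl)cc5Cl)O4)cc3)CC2)cc1)c1cccc(F)c1`: in this assay compound 3 gives > 50000 nM, also a limit.

All three values shown sit at the same limit, so the limit of > 50000 nM in this assay, at which 3 of the 3 values shown sit, is the whole of the present evidence on the amide substituent. The step from compound 1 to compound 2 reads a step that the two limits leave unreadable from compound 1 to compound 2, the step from compound 1 to compound 3 reads a step that the two limits leave unreadable from compound 1 to compound 3, and the step from compound 2 to compound 3 reads a step that the two limits leave unreadable from compound 2 to compound 3; none of them has a readable size. Compound 3 therefore stands at the limit, together with the two other values.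

Compound 4 `O=C(Nc1ccc(N2CCN(c3ccc(OC[C@@H]4CO[C@@](Cn5cncn5)(c5ccc(Cl)cc5Cl)O4)cc3)CC2)cc1)c1cccs1` differs from compound 3 by thiophen-2-yl in place of 3-fluorophenyl on a carbonyl carbon. The three measured steps on this position all bear on the change, and every one is unreadable, so no direction can be drawn from them; what they do show is that three different amide substituents all stayed at the limit. The expectation for compound 4 is accordingly a step that the limit leaves unreadable from compound 3 to compound 4 in this assay, meaning no change beyond the scatter, and most likely another limit. Compound 4 is estimated at 70000 nM, within a range from 30000 nM to 200000 nM.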

Compound 4, half-maximal inhibitory concentration: > 50000 nM
Compound 4 gave a limit, no number; the forecaster's own chance of this, stated with the estimate: 85%; the middle value is on the limit's open side.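

Compound 4 also gives a limit and not a number, so none of its steps from compound 1, compound 2 or compound 3 can be read: the limit of > 50000 nM in this assay, at which 4 of the 4 values shown sit.

The compounds shown leave open whether the propyl, ethyl, 3-fluorophenyl and thiophen-2-yl amides differ at all in this assay, and whether any amide substituent on the shared core gives a measurable value there.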